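The source may report more compounds than this note shows. Statements on the series, on what has been measured and on what is new or still open speak of the compounds shown alone.

Measured in a functional assay on A549 cells (Homo sapiens) for antiproliferative activity, read by MTT assay; a higher number here means a weaker inhibitor, a lower number a stronger inhibitor
- Compound 1 `Cc1nn2c(-c3nc4cc(C)c(C)cc4[nH]3)c(-c3ccccc3)nc2s1` gives > 30000 nM as a limit
- Compound 2 `Cc1nn2c(-c3nc4cc(Cl)c(Cl)cc4[nH]3)c(-c3ccccc3)nc2s1` gives 13600 nM
- Compound 3 `Cc1nn2c(-c3nc4c(C)c(C)ccc4[nH]3)c(-c3ccccc3)nc2s1` gives 18400 nM

The value for compound 1 is a limit and not a number. Only compound 2 and compound 3 have true numbers, and these lie within the usual scatter of each other. Compound 2 therefore stands level with compound 3, and neither can be ranked over the other.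

The next compound to be tested is compound 4 `Cc1nn2c(-c3nc4cc(Cl)c(F)cc4[nH]3)c(-c3ccccc3)nc2s1`, which keeps the core of compound 2 and differs from it in one place: fluoro in place of chloro on an aromatic carbon. This puts fluoro in place of chloro on an aromatic carbon, ortho to a chloro group.

Among the measured compounds shown here, no two measured compounds differ in one place only, so no measured step can serve as a guide. The starting point is compound 2 at 13600 nM, and a swap of one atom for one atom leads to the expectation of a small move in this assay, leaning towards a higher number and perhaps no move beyond the scatter. The estimated step is a 1.3-fold higher number from compound 2 to compound 4 (0.12 log units; within the scatter), with a limit reading still possible. For compound 4 the expected value is 18000 nM, with an estimated range from 9000 nM to 30000 nM.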

Compound 4, half-maximal inhibitory concentration: 16400 nM
Beside the measured number, compound 4's estimate is 1.1-fold (0.04 log units) above it; measured number inside the range.
By their numbers in this assay, from the lowest: compounds 2, 4 and 3 (each within the scatter of the next). At a limit, above all of these: compound 1.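

Among the compounds shown here, the first comparison in this set between two compounds that differ in one place gives, in this assay, a 1.2-fold higher number from compound 2 to compound 4 (0.08 log units; within the scatter). Compound 2 and compound 4 therefore stand level: at this aromatic carbon, ortho to a chloro group, fluoro and chloro cannot be told apart in this test, and a single measured swap now shows that this position accepts either atom without a difference that can be read. Compound 4 also gives a true number, so the comparison can be read directly, while compound 1 alone sits at a limit, which is not a number: the limit of > 30000 nM in this assay, at which 1 of the 4 values shown sits.

What the compounds shown leave open is whether a group of another kind at this same carbon, such as a methoxy group, an amine or a carboxylic acid, would give a reading in this assay that stands clearly apart from compound 2. They also leave open whether replacing the remaining chloro group would behave like this swap, since one pair of compounds speaks only for one position and one change.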